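Adding a methyl to the ethylamino chain of compound 2

The compounds below may be only part of what the source reports. "The series", "measured", "known", "first", "only" and "open" are said of these compounds alone.

Measured in an ADME assay on the whole organism for inhibition, with Oryza sativa as the target, with a stated time of 4 days (on this read-out higher numbers stand for weaker inhibition and lower numbers for stronger inhibition), so far:
compound 1 `CCCNc1nc(Cl)nc(N[C@@H](C)c2ccccc2)n1` gives 32400 nM
compound 2 `CCNc1nc(Cl)nc(N[C@H](C)c2ccccc2)n1` gives 14100 nM
compound 3 `CC[C@H](C)Nc1nc(Cl)nc(N[C@@H](C)c2ccccc2)n1` gives 6920 nM

Compound 2 holds the middle place among the three numbers, with compound 1 higher and compound 3 lower. Compound 4 `CC(C)Nc1nc(Cl)nc(N[C@H](C)c2ccccc2)n1` differs from compound 2 by methyl in place of hydrogen on a saturated chain carbon bound to a nitrogen on an aromatic ring and a saturated chain carbon in a change that reads ethylamino to isopropylamino. Within the data shown here, one measured step bears on this, the same replacement, which gave a 4.7-fold lower number from compound 1 to compound 3 (0.67 log units; beyond the scatter) on another chain. Compounds 1 and 3 also have the opposite configuration at the other amine, so that step carries over only loosely. A modest lower number in this assay is therefore expected, somewhat smaller than that step. The expected shift is a 2.6-fold lower number from compound 2 to compound 4 (0.41 log units; beyond the scatter) overall. For compound 4 the estimated value is 5500 nM within an expected range of 2000 nM to 15000 nM in this test.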

Compound 4, half-maximal inhibitory concentration: 5370 nM
The estimate for compound 4 lay 1.0-fold (0.01 log units) above the measured number; the measured number falls inside the stated range.
By their numbers in this assay, from the lowest: compounds 4 and 3 (each within the scatter of the next); then compound 2; then compound 1.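

With a 2.6-fold lower number from compound 2 to compound 4 (0.42 log units; beyond the scatter) in this assay, the methyl on this saturated chain carbon lowers the number on a compound with the opposite configuration at the other amine. The earlier step showed this change with only one configuration, and the result now extends it to both. The change gives steps of similar size on the two cores: the same change on two cores in this assay, a 4.7-fold lower number (0.67 log units; beyond the scatter) from compound 1 to compound 3 and a 2.6-fold lower number (0.42 log units; beyond the scatter) from compound 2 to compound 4, 1.8-fold (0.25 log units) apart, within the scatter of two such steps.

As far as these compounds go, it remains open whether a tert-butyl or cyclopropyl group on the amine would lower the number further. The effect of the configuration at the other amine, taken alone, also cannot be read from these compounds.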